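Para Hydroxy in Place of Hydrogen on the Aryl Ring

The compounds below may be only part of what the source reports. "The series", "measured", "known", "first", "only" and "open" are said of these compounds alone.

Compound 2 `C=CC[C@H]1C[C@]2([C@@H](C)Cc3ccccc3)OCOC2=CC1=O` gives the highest of the two numbers recorded in a functional assay on M14 cells (Homo sapiens) for antiproliferative activity, with a stated time of 72 h (on this read-out lower numbers stand for stronger inhibition and higher numbers for weaker inhibition), at 5100 nM; its nearest neighbour, compound 1 `C=CC[C@H]1C[C@]2([C@@H](C)Cc3ccc(OC)cc3)OCOC2=CC1=O`, reaches 20 nM. Among the measured compounds shown here, the only measured step, a 260-fold higher number from compound 1 to compound 2 (2.41 log units; beyond the scatter), shows how strongly this aromatic position matters. Compound 3 `C=CC[C@H]1C[C@]2([C@@H](C)Cc3ccc(O)cc3)OCOC2=CC1=O` brings (hydroxy in place of hydrogen on an aromatic carbon). Since a methoxy at that same position produced the step from compound 1 to compound 2 in reverse, a hydroxy there is expected to move the number back down by a large margin, though perhaps not fully, giving a 43-fold lower number from compound 2 to compound 3 (1.63 log units; beyond the scatter). Compound 3 is therefore estimated at 120 nM, within a range of 15 nM to 1000 nM.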

Compound 3, half-maximal inhibitory concentration: > 20000 nM
Compound 3: only a limit was reported; the forecaster's own chance of this, stated with the estimate: 2%; middle value at least 160-fold (2.22 log units) from the limit.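

Compound 3 reads > 20000 nM in this assay, which is a limit of the assay and not a number. The hydroxy does not restore activity to the phenyl compound, giving an at least 3.9-fold higher number from compound 2 to compound 3 (0.59 log units; beyond the scatter), and taking the methyl off the oxygen of compound 1 gives an at least 1000-fold higher number from compound 1 to compound 3 (3.00 log units; beyond the scatter). Among these compounds, then, an oxygen at this place is not enough on its own: methoxy and hydroxy fall on opposite sides of the unsubstituted phenyl. The compounds shown leave open whether an ethoxy, an amine or a fluorine at this position would keep the low number of compound 1.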